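Hydroxyethyl for isopropyl at the amide-linked chain carbon

The compounds below may be only part of what the source reports. "The series", "measured", "known", "first", "only" and "open" are said of these compounds alone.

Measured compounds:
Compound 1 `Cc1cccc(C(=O)N[C@@H](CC(C)C)C(=O)NCCNc2ccc(Cl)cc2)c1` — in an assay on isolated protein for inhibition of cathepsin S (Homo sapiens) (on this read-out lower numbers stand for stronger inhibition and higher numbers for weaker inhibition), compound 1 gives 458 nM
Compound 2 `COc1ccc(NC[C@H](C)NC(=O)[C@H](CC(C)C)NC(=O)c2cccc(C)c2)cc1` — in this assay compound 2 gives 15 nM
Compound 3 `COc1cccc(C(=O)N[C@@H](CCC2CCCCC2)C(=O)N[C@H](CN2CCc3cc(F)ccc32)C(C)C)c1` — in this assay compound 3 gives 14 nM

Compound 3 holds the lowest of the three numbers in this assay. Compound 2 sits so close that the two are within the usual scatter and no order can be read between them; compound 1 lies far above both, beyond the scatter.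

Compound 4 `COc1cccc(C(=O)N[C@@H](CCC2CCCCC2)C(=O)N[C@H](CN2CCc3cc(F)ccc32)[C@@H](C)O)c1` differs from compound 3 in one place: 1-hydroxyethyl in place of isopropyl on a saturated chain carbon bound to an amide-type nitrogen and a saturated chain carbon. For the measured compounds named here, no pair of measured compounds shows this exchange, so nothing gives the size or direction of the step directly. Compounds 1 and 2 carry other groups at this chain carbon and other cores, and they do not frame the change either.

The working expectation is a step in this assay of a 1.8-fold higher number from compound 3 to compound 4 (0.25 log units; within the scatter), on the side of a somewhat higher number, of a size that may or may not clear the scatter. Compound 4 is thus estimated at 25 nM, with a range from 8 nM to 80 nM, the wide range reflecting the absence of a measured step for this exchange.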

Compound 4, inhibition constant: 8 nM
For compound 4 the middle estimate is 3.1-fold (0.49 log units) above the measured one; the measured number falls inside the stated range.
By their numbers in this assay, from the lowest: compounds 4, 3 and 2 (each within the scatter of the next); then compound 1.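

In this assay, for the compounds shown here, the first measured step at this position is a 1.8-fold lower number from compound 3 to compound 4 (0.24 log units; within the scatter), for 1-hydroxyethyl in place of isopropyl on a saturated chain carbon bound to an amide-type nitrogen and a saturated chain carbon. The earlier compounds shown here gave no reading of this position, and this pair shows that a group carrying a hydrogen-bond donor and acceptor can stand here in place of a purely carbon group without a step that clears the scatter, so compound 3 and compound 4 cannot be ordered. Nothing at hand accounts for this result, and the pair alone gives the outcome of the exchange but no reason for it.

The compounds shown leave open how an aminoethyl group, a carboxylic acid or a longer chain such as n-butyl would read at this chain carbon, and whether the opposite configuration of the 1-hydroxyethyl stereocentre would read the same. They also leave open whether the same exchange gives a similar step on a different core, such as those of compound 1 and compound 2.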